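Swapping chloro for 4-bromophenoxy on compound 2

A few compounds are considered here, and "the series" means these few. Any claim that something is new, unique, unknown or untested is made for them only; others in the source may bear on it.

- Compound 1 `COc1ccc(/C=C/C(=O)/C=C/c2cc3ccccc3nc2Cl)cc1`: > 10000 nM (a limit)
- Compound 2 `COc1ccc(/C=C/C(=O)/C=C/c2cc3ccccc3nc2Cl)c(OC)c1`: > 10000 nM (a limit)
- Compound 3 `COc1cc(OC)c(OC)cc1/C=C/C(=O)/C=C/c1cc2ccccc2nc1Cl`: 1810 nM

All three values come from a functional assay on 4T1 cells (Mus musculus) for cytotoxicity, read by MTT assay, with a stated time of 48 h; a higher number here means a weaker inhibitor, a lower number a stronger inhibitor. Compound 2 stands at the limit of > 10000 nM in this assay, at which 2 of the 3 values shown sit, so it has a limit and not a number. For the measured compounds named here, two measured steps touch it, and each places a methoxy in place of hydrogen on an aromatic carbon. Going by the values given here, the first is a step that the two limits leave unreadable from compound 1 to compound 2. The second is an at least 5.5-fold lower number from compound 2 to compound 3 (0.74 log units; beyond the scatter).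

The next change lies elsewhere. Compound 4 `COc1ccc(/C=C/C(=O)/C=C/c2cc3ccccc3nc2Oc2ccc(Br)cc2)c(OC)c1` differs from compound 2 by 4-bromophenoxy in place of chloro on an aromatic carbon. The chloro leaves an aromatic carbon next to the ring nitrogen, and 4-bromophenoxy enters there.

Neither methoxy step changes that place, so both bear on this one only loosely. Still, an at least 5.5-fold lower number from compound 2 to compound 3 (0.74 log units; beyond the scatter) shows that a single change can bring a compound of this kind off the limit. A modest move towards a lower number is therefore expected in this assay, though compound 4 may well stay at the limit. Compound 4 is estimated at 5000 nM, with an expected range from 1500 nM to 15000 nM. The estimated step is an at least 2.0-fold lower number from compound 2 to compound 4 (0.30 log units; that floor lies within the scatter).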

Compound 4, half-maximal inhibitory concentration: > 10000 nM
Compound 4: a limit, no number; the forecaster's own chance of this, stated with the estimate: 40%; middle value at least 2.0-fold (0.30 log units) from the limit.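

In this assay compound 4 gives > 10000 nM as a limit and not a number. For the compounds shown here, compound 2 also carries a limit, so no step from compound 2 to compound 4 can be read: the limit of > 10000 nM in this assay, at which 3 of the 4 values shown sit. The compounds shown leave open whether 4-bromophenoxy in place of chloro changes the number at all, and in which direction.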